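The source may hold more compounds than are shown below. What is called first, only, known or untested is meant among the compounds shown, and "the series" means these compounds.

Measured in an assay on isolated protein for inhibition of Dopamine beta-hydroxylase (Rattus norvegicus); a higher number here means a weaker inhibitor, a lower number a stronger inhibitor:
- compound 1 `Cc1cc(Cn2cc[nH]c2=S)ccc1O` gives 49000 nM
- compound 2 `COc1ccc(Cn2cc[nH]c2=S)cc1Br` gives 83200 nM
- compound 3 `Oc1ccc(Cn2cc[nH]c2=S)cc1C(F)(F)F` gives 120000 nM

Compound 3 has the highest number of the three in this assay; compound 2 lies within the scatter of it, compound 1 beyond it. Among the compounds with values here, the single one-place step in the set, a 2.4-fold higher number from compound 1 to compound 3 (0.39 log units; beyond the scatter), is modest. Compound 4 `Oc1ccc(Cn2cc[nH]c2=S)cc1Br` is compound 3 with bromo in place of trifluoromethyl on an aromatic carbon. Within the data shown here, no measured step covers this change; compound 2 carries bromo but differs from compound 4 elsewhere, so its value only hints that bromo sits in the same region. A step of a 1.7-fold lower number from compound 3 to compound 4 (0.23 log units; within the scatter) is expected, towards a lower number. For compound 4 the estimate is 70000 nM, within 30000 nM to 160000 nM.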

Compound 4, half-maximal inhibitory concentration: 12000 nM
Beside the measured number, compound 4's estimate is 5.8-fold (0.77 log units) above it; the measured number lies below the stated range.
By their numbers in this assay, from the lowest: compound 4; then compounds 1, 2 and 3 (each within the scatter of the next, the first and the last beyond it).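

In this assay, the aromatic carbon ortho to a hydroxy group discriminates among its substituents, with bromo giving a lower number than both trifluoromethyl (a 10-fold lower number from compound 3 to compound 4 (1.00 log units; beyond the scatter)) and methyl (a 4.1-fold lower number from compound 1 to compound 4 (0.61 log units; beyond the scatter)). With bromo held constant, the free hydroxy group gives a lower number than its methyl ether (a 6.9-fold lower number from compound 2 to compound 4 (0.84 log units; beyond the scatter)). Nothing available bears on the reason for these steps.

Going by these compounds, whether chloro, an amine or a carboxylic acid at this carbon would match bromo remains open. So does how hydrogen there compares.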